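A few compounds are considered here, and "the series" means these few. Any claim that something is new, unique, unknown or untested is made for them only; others in the source may bear on it.

Working notes on compound 1 `O=C(COc1ccc2c(=O)cc(-c3ccccc3)oc2c1)Nc1ccccc1` and its neighbours in a functional assay on MT2 cells (Homo sapiens) for antiproliferative activity, read by MTT assay, with a stated time of 72 h (a higher number here means a weaker inhibitor of growth, a lower number a stronger inhibitor of growth), follow. Compound 1 sits at > 10000 nM as a limit of the assay and not a number. Compound 2 `O=C(COc1ccc2c(=O)cc(-c3ccccc3)oc2c1)Nc1ccc(F)cc1` gives 6410 nM and compound 3 `COc1ccc(NC(=O)COc2ccc3c(=O)cc(-c4ccccc4)oc3c2)cc1` gives 6700 nM so these two stand level within the scatter. The next change leads to compound 4 `O=C(COc1ccc2c(=O)cc(-c3ccccc3)oc2c1)Nc1ccc(-c2ccccc2)cc1` through phenyl in place of methoxy on an aromatic carbon (phenyl in place of methoxy on an aromatic carbon, para to a large group). Among the measured compounds shown here, three measured steps bear on it, namely an at least 1.5-fold lower number from compound 1 to compound 2 (0.19 log units; that floor lies within the scatter) and an at least 1.4-fold lower number from compound 1 to compound 3 (0.17 log units; that floor lies within the scatter) and a 1.0-fold higher number from compound 2 to compound 3 (0.02 log units; within the scatter) and none of them gives a firm step beyond the scatter. None of them brings in a ring, so they guide only loosely. On that basis no step beyond the scatter is expected in this assay for this change. The estimated step is a 1.0-fold lower number from compound 3 to compound 4 (0.01 log units; within the scatter) and it is expected to stay small. Compound 4 could also end at the limit of > 10000 nM in this assay, at which 1 of the 3 values shown sits, as compound 1 did. For compound 4 the estimated value is 6500 nM with an expected range from 2500 nM to 15000 nM in this estimate.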

Compound 4, concentration for 50% growth inhibition: 2480 nM
The estimate for compound 4 lay 2.6-fold (0.42 log units) above the measured number; the measured number lies below the stated range.
By their numbers in this assay, from the lowest: compound 4; then compounds 2 and 3 (each within the scatter of the next). At a limit, above all of these: compound 1.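

In this assay, phenyl in place of methoxy gives a 2.7-fold lower number from compound 3 to compound 4 (0.43 log units; beyond the scatter) and phenyl in place of fluoro gives a 2.6-fold lower number from compound 2 to compound 4 (0.41 log units; beyond the scatter) on an aromatic carbon, para to a large group, so this position can respond beyond the scatter, although fluoro and methoxy stood level there. Phenyl in place of hydrogen gives an at least 4.0-fold lower number from compound 1 to compound 4 (0.60 log units; beyond the scatter) and this step is only a floor. Compound 1 stands at a limit of the assay and not a number: the limit of > 10000 nM in this assay, at which 1 of the 4 values shown sits.

On these data alone, whether the step follows the aromatic ring itself or simply a group of more heavy atoms stays open, and a cyclohexyl ring or a butyl chain at this place would separate the two. As far as these compounds go, how an amine or a carboxylic acid would read here in this assay is also open.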